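The source may hold more compounds than are shown below. What is called first, only, known or untested is meant among the compounds shown, and "the series" means these compounds.

In an ADME assay on J774.A1 cells (Mus musculus) for cytotoxicity, read by MTT assay, with a stated time of 48 h (on this read-out lower numbers stand for higher toxicity in this test and higher numbers for lower toxicity in this test), the compounds measured so far are:

- Compound 1 (`C/C(=C\c1ccccc1)C(=O)/C=C/c1ccc([N+](=O)[O-])cc1`): 26000 nM
- Compound 2 (`C/C(=C\c1ccc([N+](=O)[O-])cc1)C(=O)/C=C/c1ccc([N+](=O)[O-])cc1`): 43000 nM
- Compound 3 (`C/C(=C\c1ccc([N+](=O)[O-])cc1)C(=O)/C=C/c1ccc(N(C)C)cc1`): 24700 nM

Compound 2 does not separate from the other two on these numbers. The measured steps are a 1.7-fold higher number from compound 1 to compound 2 (0.22 log units; within the scatter) and a 1.7-fold lower number from compound 2 to compound 3 (0.24 log units; within the scatter), and neither leaves the scatter.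

Compound 4 (`C/C(=C\c1ccc(N(C)C)cc1)C(=O)/C=C/c1ccc([N+](=O)[O-])cc1`) has not yet been measured. Its difference from compound 2 is dimethylamino in place of nitro on an aromatic carbon.

Among the compounds with values here, two measured steps bear on this change. The step of a 1.7-fold lower number from compound 2 to compound 3 (0.24 log units; within the scatter) is the same exchange made on the other aromatic ring. The step of a 1.7-fold higher number from compound 1 to compound 2 (0.22 log units; within the scatter) places the nitro on the carbon that changes here. Both are small, so no shift beyond the scatter is expected in this assay, at most a slight drift toward a lower number. The expected change is a 1.6-fold lower number from compound 2 to compound 4 (0.20 log units; within the scatter). For compound 4 the estimate is 27000 nM, with an expected range from 13000 nM to 52000 nM.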

Compound 4, half-maximal cytotoxic concentration: 967000 nM
Compound 4: middle estimate off by 36-fold (1.55 log units), on the low side; measured number above the stated range.
By their numbers in this assay, from the lowest: compounds 3, 1 and 2 (each within the scatter of the next); then compound 4.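

In this assay, dimethylamino on this aromatic carbon, para to a large group, gives a 22-fold higher number from compound 2 to compound 4 (1.35 log units; beyond the scatter) and also a 37-fold higher number from compound 1 to compound 4 (1.57 log units; beyond the scatter), so here the group moves the number well beyond the scatter whether it replaces nitro or hydrogen. The earlier compounds shown here showed nothing of this: nitro in place of hydrogen at this carbon gave only a 1.7-fold higher number from compound 1 to compound 2 (0.22 log units; within the scatter), and the same exchange of nitro for dimethylamino on the other aromatic ring gave only a 1.7-fold lower number from compound 2 to compound 3 (0.24 log units; within the scatter), so in these compounds the outcome of that exchange differs with the ring that carries it. Nothing given here explains this difference.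

Going by these compounds, it remains open whether a primary amine, a methoxy group or a diethylamino group on this carbon would give a similarly high number. On these data alone, it is also open whether the high number would hold if the nitro on the other aromatic ring gave way to an amine or a carboxylic acid.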